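The source may report more compounds than this note shows. Statements on the series, on what has been measured and on what is new or still open speak of the compounds shown alone.

Measured compounds:
compound 1 `COc1ccc(-c2nc(C)oc2C(=O)N2CCN(c3cccc(Cl)c3)CC2)cc1` — "not active" (no number reported)
compound 2 `Cc1nc(-c2ccccc2F)c(C(=O)N2CCN(c3cccc(Cl)c3)CC2)o1` — 39.4 nM

The study compares two compounds in a functional assay on HL-60 cells (Homo sapiens) for inhibition, read by MTT assay, with a stated time of 72 h; on this read-out lower numbers stand for stronger inhibition and higher numbers for weaker inhibition. Compound 1 `COc1ccc(-c2nc(C)oc2C(=O)N2CCN(c3cccc(Cl)c3)CC2)cc1` gives "not active" (no number reported) there, with no number reported. Compound 2 `Cc1nc(-c2ccccc2F)c(C(=O)N2CCN(c3cccc(Cl)c3)CC2)o1` gives 39.4 nM in this assay. Within the data shown here, compound 2 therefore stands as the only compound with a number on this read-out; the other entry offers nothing to rank it against.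

The next compound, compound 3 `CCc1nc(-c2ccccc2F)c(C(=O)N2CCN(c3cccc(Cl)c3)CC2)o1`, has not yet been measured in this assay. It differs from compound 2 in one place: methyl in place of hydrogen on a saturated chain carbon bound to an aromatic carbon. Cut one bond further out, the same change reads methyl to ethyl.

Among the measured compounds shown here, no step between measured compounds is available to guide expectations here. Since the change adds a single carbon and nothing else, the step from compound 2 to compound 3 in this assay is expected to be small, most likely no larger than the usual scatter of repeated measurements, in either direction. The writer expects a 1.1-fold higher number from compound 2 to compound 3 (0.06 log units; within the scatter). Compound 3 is thus estimated at 45 nM in this assay, within a range from 15 nM to 140 nM.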

Compound 3, half-maximal inhibitory concentration: 139 nM
Compound 3: middle estimate off by 3.1-fold (0.49 log units), on the low side; low and high end bracket the measured number.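

In this assay, the change of methyl to ethyl, which is methyl in place of hydrogen on a saturated chain carbon bound to an aromatic carbon, gives a 3.5-fold higher number from compound 2 to compound 3 (0.55 log units; beyond the scatter). Among these compounds, this is the first step between measured compounds, and it shows that this position responds to a single added carbon, with the longer chain going with weaker inhibition in this one pair. No measured evidence on the compounds accounts for a step of this size from so small a change.

The compounds shown leave open whether inhibition keeps weakening along a longer chain such as propyl, or whether a branched group such as isopropyl, a cyclopropyl ring or a chain ending in an amine would read differently at this position. They also leave open whether methyl to ethyl would give a step of similar size on the core of compound 1, which carries a methoxy group where compound 2 carries fluorine, since a single pair cannot show whether the step holds elsewhere.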